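From Diethylamino to Dipropylamino

The source may hold more compounds than are shown below. What is called first, only, known or untested is meant among the compounds shown, and "the series" means these compounds.

In a functional assay on the whole organism for positive allosteric modulation, with Mus musculus as the target (a higher number here means that more compound is needed for the effect, a lower number that less compound is needed), compound 1 (`CCC(=O)N(c1ccc(Cl)c(Cl)c1)C1CCCC1O`) gives 0.4 mg/kg, compound 2 (`CCNC1CCCC1N(C(=O)CC)c1ccc(Cl)c(Cl)c1`) gives 0.2 mg/kg and compound 3 (`CCC(=O)N(c1ccc(Cl)c(Cl)c1)C1CCCC1N(CC)CC`) gives 0.1 mg/kg. These numbers show a 4.0-fold lower number from compound 1 to compound 3 (0.60 log units; beyond the scatter), a real gap, but also a 2.0-fold lower number from compound 2 to compound 3 (0.30 log units; within the scatter), which cannot be told apart from noise. Compound 4 (`CCCN(CCC)C1CCCC1N(C(=O)CC)c1ccc(Cl)c(Cl)c1`) carries dipropylamino in place of diethylamino on a saturated ring carbon. Within the data shown here, no measured step lengthens a chain on this amine, so the closest guide is the swap of hydrogen for ethyl on an amine nitrogen, a 2.0-fold lower number from compound 2 to compound 3 (0.30 log units; within the scatter). No step beyond the scatter is therefore expected in this assay, and the estimate is no change at the digits printed from compound 3 to compound 4 (within the scatter). Compound 4 is expected at 0.1 mg/kg, with an estimated range of 0.04 mg/kg to 0.3 mg/kg.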

Compound 4, dose for half-maximal effect: 2 mg/kg
For compound 4 the middle estimate is 20-fold (1.30 log units) below the measured one; measured number outside the range, above it.
By their numbers in this assay, from the lowest: compounds 3, 2 and 1 (each within the scatter of the next, the first and the last beyond it); then compound 4.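

In this assay this position proves sensitive to the length of the chains on the amine: a 20-fold higher number from compound 3 to compound 4 (1.30 log units; beyond the scatter) comes from a change that adds only carbon and leaves the hydrogen-bond donor and acceptor counts unchanged. Carrying an amine here is not enough for a low number, since a 10-fold higher number from compound 2 to compound 4 (1.00 log units; beyond the scatter) and a 5.0-fold higher number from compound 1 to compound 4 (0.70 log units; beyond the scatter) leave dipropylamino behind both ethylamino and even hydroxy. Nothing available explains this jump. Still open, on these data alone, is whether the rise comes gradually, as an ethylpropylamino group would show, or depends on total size, as dibutylamino would show. A ring amine such as pyrrolidine would test whether the chains must be free.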